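Methyl to Methoxy on the Phenoxy Ring of Compound 3

The source may hold more compounds than are shown below. What is called first, only, known or untested is meant among the compounds shown, and "the series" means these compounds.

Compound 1 `Cc1nn(C)c(Oc2ccc(F)cc2)c1/C=N\OCc1c(Cl)c(-c2ccc(Cl)cc2)nn1C` gives 80% in a functional assay on SMMC-7721 cells (Homo sapiens) for inhibition, read by MTT assay, with a stated time of 72 h, tested at 25 uM; on this read-out higher numbers stand for more inhibition at the one concentration tested (going by the name of the read-out) and lower numbers for less inhibition.
Compound 3 `Cc1ccc(Oc2c(/C=N\OCc3c(Cl)c(-c4ccc(Cl)cc4)nn3C)c(C)nn2C)cc1` gives 80% in this assay.
Compound 2 `CCc1nn(C)c(CO/N=C\c2c(C)nn(C)c2Oc2ccc(OC)cc2)c1Cl` reports only a limit in this assay, < 80%.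

Compound 3 stands level with compound 1, the step of no change at the digits printed from compound 1 to compound 3 (within the scatter) lying within the scatter. Compound 4 `COc1ccc(Oc2c(/C=N\OCc3c(Cl)c(-c4ccc(Cl)cc4)nn3C)c(C)nn2C)cc1` differs from compound 3 in one place: methoxy in place of methyl on an aromatic carbon. Among the compounds with values here, no measured step covers this exchange directly; the only one, no change at the digits printed from compound 1 to compound 3 (within the scatter), involves the same ring and shows no movement. Compound 2, which carries a 4-methoxyphenoxy group, sits at the limit of < 80% in this assay, at which 1 of the 3 values shown sits, which leaves some doubt. Compound 4 is therefore expected near 72%, between 50% and 88%. The expected step of a number 8 percentage points lower from compound 3 to compound 4 (within the scatter) is estimated to stay within the scatter, leaning slightly lower.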

Compound 4, a percentage reported as inhibition, at one concentration (the size of the read-out at that concentration, not a potency): 80%
Compound 4: the middle estimate sits 8 percentage points below what was measured; the measured number falls inside the stated range.
By their numbers in this assay, from the lowest: compounds 1, 3 and 4 (each within the scatter of the next).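

Methoxy in place of methyl gives no change at the digits printed from compound 3 to compound 4 (within the scatter), and methoxy in place of fluoro gives no change at the digits printed from compound 1 to compound 4 (within the scatter). In this assay, this aromatic carbon, para to a large group, thus carries fluoro, methyl or methoxy, including the hydrogen-bond acceptor counted for methoxy, without any separation among compound 1, compound 3 and compound 4. Compound 2 gives only a limit: the limit of < 80% in this assay, at which 1 of the 4 values shown sits. The exchange of 4-chlorophenyl in place of ethyl gives a number no lower from compound 2 to compound 4 (the limit leaves the size open), so the size of this step cannot be read.

On these data alone, what an amine or a carboxylic acid on this carbon would do remains open. So does whether a longer chain in place of methoxy would leave the read-out unchanged.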